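Aryl swap on the carbinol carbon: cytotoxicity notes

The source may report more compounds than this note shows. Statements on the series, on what has been measured and on what is new or still open speak of the compounds shown alone.

Measured compounds:
compound 1 `Cc1cc(S(N)(=O)=O)ccc1NC(=O)COc1ccc(Cl)cc1C(O)c1ccccc1C` gives 33900 nM
compound 2 `Cc1cc(S(N)(=O)=O)ccc1NC(=O)COc1ccc(Cl)cc1C(O)c1ccccc1Cl` gives 32000 nM
compound 3 `Cc1cc(C)cc(C(O)c2cc(Cl)ccc2OCC(=O)Nc2ccc(S(N)(=O)=O)cc2C)c1` gives 29400 nM

All three values come from an ADME assay on C8166 cells (Homo sapiens) for cytotoxicity, read by MTT assay; a lower number here means that less compound is tolerated, a higher number that more compound is tolerated. Compound 2 sits in the middle of the three numbers: its nearest neighbour is compound 1, which lies a 1.1-fold lower number from compound 1 to compound 2 (0.03 log units; within the scatter) away, and its furthest is compound 3, at a 1.1-fold lower number from compound 2 to compound 3 (0.04 log units; within the scatter). Both gaps are within the scatter, so the three measured compounds cannot be told apart on this assay.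

The next compound is compound 4 `Cc1cc(S(N)(=O)=O)ccc1NC(=O)COc1ccc(Cl)cc1C(O)c1cccc2ccccc12`. It differs from compound 2 at one place: naphthalen-1-yl in place of 2-chlorophenyl on a saturated chain carbon bound to an aromatic carbon and an oxygen on a saturated carbon.

For the measured compounds named here, two measured steps touch the same position, the saturated chain carbon bound to an aromatic carbon and an oxygen on a saturated carbon. Going from compound 1 to compound 3 gave a 1.2-fold lower number from compound 1 to compound 3 (0.06 log units; within the scatter), and from compound 2 to compound 3 gave a 1.1-fold lower number from compound 2 to compound 3 (0.04 log units; within the scatter). Neither exchange of the aryl group at this carbon moved this assay beyond the scatter, and the chloro-for-methyl swap elsewhere, a 1.1-fold lower number from compound 1 to compound 2 (0.03 log units; within the scatter), was equally flat. Going by the values given here, no step of any size is therefore expected for this assay from the change to naphthalen-1-yl; the expected step is a 1.1-fold lower number from compound 2 to compound 4 (0.03 log units; within the scatter).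

For compound 4 the estimate in this assay is 30000 nM, with a range from 15000 nM to 60000 nM.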

Compound 4, half-maximal cytotoxic concentration: 31100 nM
Compound 4: the middle estimate sits 1.0-fold (0.02 log units) below what was measured; the range from low to high includes it.
By their numbers in this assay, from the lowest: compounds 3, 4, 2 and 1 (each within the scatter of the next).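

In this assay a second aromatic ring at this position changes nothing that can be read: going to naphthalen-1-yl, with 10 heavy atoms and 2 six-membered aromatic rings, gives no step beyond the scatter from any of the three single-ring aryl groups (a 1.0-fold lower number from compound 2 to compound 4 (0.01 log units; within the scatter); a 1.1-fold higher number from compound 3 to compound 4 (0.02 log units; within the scatter); a 1.1-fold lower number from compound 1 to compound 4 (0.04 log units; within the scatter)). The flat response on the saturated chain carbon bound to an aromatic carbon and an oxygen on a saturated carbon therefore now covers 2-methylphenyl, 2-chlorophenyl, 3,5-dimethylphenyl and naphthalen-1-yl, and no compound among these four goes against it. Nothing available accounts for this flat response.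

On these data alone, whether it holds for groups other than carbon-ring aryl groups remains open, for example an aryl group carrying an amine or a carboxylic acid, or a longer saturated chain in place of the aryl group. Also open is whether any change at this carbon can produce a step beyond the scatter in this assay at all, since all four compounds shown share the rest of the core unchanged.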